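Replacing the dimethylpyrazole of compound 2

The source may hold more compounds than are shown below. What is called first, only, known or untested is meant among the compounds shown, and "the series" means these compounds.

In a physicochemical assay for solubility, read by chemiluminescence, in phosphate buffer, measured as kinetic solubility, at pH 7.4 (a higher number here means a more soluble compound, a lower number a less soluble compound), compound 2 (`Cc1cc(C)n(-c2ccc(C(=O)NCC3(c4nc(-c5ccccc5)cs4)CCOCC3)cc2)n1`) gives 33000 nM as the lowest of three numbers. Compound 1 (`O=C(NCC1(c2nc(-c3ccccc3)cs2)CCOCC1)c1ccc(-c2cnco2)cc1`) gives 71000 nM and compound 3 (`COc1cccc(-c2csc(C3(CNC(=O)c4ccc(Cn5nc(C)cc5C)cc4)CCOCC3)n2)c1`) gives 72000 nM in the same read-out, and those two values lie within the scatter of each other.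

Compound 4 (`O=C(NCC1(c2nc(-c3ccccc3)cs2)CCOCC1)c1ccc(Nc2nncs2)cc1`) departs from compound 2 at one place ((1,3,4-thiadiazol-2-yl)amino in place of 3,5-dimethyl-1H-pyrazol-1-yl on an aromatic carbon) with (1,3,4-thiadiazol-2-yl)amino in place of 3,5-dimethyl-1H-pyrazol-1-yl on an aromatic carbon, para to a large group.

Within the data shown here, one measured step bears on this place, and it is modest: a 2.2-fold lower number from compound 1 to compound 2 (0.33 log units; beyond the scatter) came with 3,5-dimethyl-1H-pyrazol-1-yl in place of 1,3-oxazol-5-yl on an aromatic carbon. Among the measured compounds shown here, compound 3 is tied to the others by no single-place step and gives no direct guide. For the measured compounds named here, no measured compound carries the (1,3,4-thiadiazol-2-yl)amino group, so that one step guides the expected size only and sets no firm direction. The expected move in this assay is a 1.2-fold higher number from compound 2 to compound 4 (0.08 log units; within the scatter) and so nothing beyond the scatter is expected. For compound 4 the estimate is 40000 nM with an expected range from 13000 nM to 80000 nM in this read-out.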

Compound 4, solubility: 29000 nM
Estimate against measurement, compound 4: 1.4-fold (0.14 log units) above; the range from low to high includes it.
By their numbers in this assay, from the lowest: compounds 4 and 2 (each within the scatter of the next); then compounds 1 and 3 (each within the scatter of the next).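

Notes on the aromatic carbon para to a large group: in this assay, (1,3,4-thiadiazol-2-yl)amino in place of 3,5-dimethyl-1H-pyrazol-1-yl gives a 1.1-fold lower number from compound 2 to compound 4 (0.06 log units; within the scatter), so this exchange of ring and attachment leaves the read-out within the scatter, even though the entering group has 1 hydrogen-bond donor and the leaving group has 0. Against the 1,3-oxazol-5-yl group, the same position gives a 2.4-fold lower number from compound 1 to compound 4 (0.39 log units; beyond the scatter), in the same direction as a 2.2-fold lower number from compound 1 to compound 2 (0.33 log units; beyond the scatter), and among these three compounds that differ only at this place, compound 1 alone stands apart from the other two. Nothing available accounts for the result or for the separation of compound 1.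

Still open, going by these compounds, is whether the separation of compound 1 belongs to the 1,3-oxazol-5-yl ring itself or would also appear with other rings, such as a 1,3,4-thiadiazol-2-yl group joined directly to the aromatic carbon without the amino link. Also open, on these data alone, is how far this assay can move at this position with a quite different group, such as a carboxylic acid or a dimethylamino group.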